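Hydroxy in place of methyl: an expected inhibition value

This account rests on a few compounds, and the source may have more. Where it says the series, first, only, none or still open, it means among the compounds named here.

Within the data shown here, in an assay on isolated protein for inhibition of Neprilysin (Oryctolagus cuniculus) (a higher number here means a weaker inhibitor, a lower number a stronger inhibitor), compound 3 `Cc1ccc([C@H]2CC[C@@H](C(=O)O)N2C(=O)CNC(=O)[C@@H](S)Cc2ccc(O)cc2)cc1` gives 5.5 nM, the lowest of the three numbers measured so far. Compound 1 `Cc1ccccc1[C@@H]1CC[C@H](C(=O)O)N1C(=O)CNC(=O)[C@@H](S)Cc1ccccc1` gives 8.5 nM in this assay, within the scatter of compound 3, while compound 2 `Cc1ccccc1[C@H]1CC[C@H](C(=O)O)N1C(=O)CNC(=O)[C@@H](S)Cc1ccccc1` gives 25 nM. Among the measured compounds shown here, the only measured single-site step, a 2.9-fold higher number from compound 1 to compound 2 (0.47 log units; beyond the scatter), rests on the fact that compounds 1 and 2 differ only in the configuration as drawn and is modest. Compound 4 `O=C(NCC(=O)N1[C@@H](c2ccc(O)cc2)CC[C@H]1C(=O)O)[C@@H](S)Cc1ccc(O)cc1` differs from compound 3 by hydroxy in place of methyl on an aromatic carbon. For the measured compounds named here, no measured step touches this kind of change, so the measured data give no direction for it. The step is therefore expected to be small, a 1.1-fold higher number from compound 3 to compound 4 (0.04 log units; within the scatter), not beyond the scatter. Compound 4 is accordingly estimated at 6 nM, with a range from 2 nM to 18 nM.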

Compound 4, half-maximal inhibitory concentration: 6.36 nM
Compound 4: the middle estimate sits 1.1-fold (0.03 log units) below what was measured; measured number inside the range.
By their numbers in this assay, from the lowest: compounds 3, 4 and 1 (each within the scatter of the next); then compound 2.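

In this assay, among these compounds, the change from 4-methylphenyl to 4-hydroxyphenyl gives a 1.2-fold higher number from compound 3 to compound 4 (0.06 log units; within the scatter) and is the first measured step at this place on the aromatic ring. At this position, para to a large group, hydroxy and methyl are therefore not told apart in this pair, although hydroxy brings a hydrogen-bond donor and acceptor that methyl lacks. Going by these compounds, whether an amine or a carboxylic acid at the same position would also stay within the scatter remains open. Nothing available bears on why this step is small.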